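The source may hold more compounds than are shown below. What is called first, only, known or untested is meant among the compounds shown, and "the series" means these compounds.

Of the compounds shown here, two have been measured in an assay on cells for inhibition of Palmitoleoyl-protein carboxylesterase NOTUM variant C330S (Homo sapiens), read by fluorescence, with a stated time of 40 min; on this read-out higher numbers stand for weaker inhibition and lower numbers for stronger inhibition. Compound 1, `Cc1cc(C(=O)O)c(C)n1-c1cccc(C#N)c1`, gives 3100 nM. Compound 2, `Cc1cccc(N2CCC(C(=O)O)C2)c1`, gives 49000 nM, the higher of the two numbers, and its distance from compound 1 lies beyond the usual scatter of repeated measurements of this kind. Compound 3, `O=C(O)C1CCN(c2cccc(OC(F)(F)F)c2)C1`, has not yet been measured in this assay. It differs from compound 2 by a single exchange: trifluoromethoxy in place of methyl on an aromatic carbon. Among the measured compounds shown here, no measured pair shows this same exchange, so the size of its effect cannot be read from the two values in hand. On that basis the expected step from compound 2 to compound 3 is a 2.5-fold lower number from compound 2 to compound 3 (0.39 log units; beyond the scatter), a modest move toward stronger inhibition that chance alone could still account for. Compound 3 is therefore estimated at 20000 nM in this assay, with a plausible range from 5000 nM to 80000 nM.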

Compound 3, half-maximal inhibitory concentration: 63000 nM
Beside the measured number, compound 3's estimate is 3.2-fold (0.50 log units) below it, within the range that was stated.
By their numbers in this assay, from the lowest: compound 1; then compounds 2 and 3 (each within the scatter of the next).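

In this assay, putting trifluoromethoxy in place of methyl on this aromatic carbon gives a 1.3-fold higher number from compound 2 to compound 3 (0.11 log units; within the scatter). The two compounds therefore cannot be told apart on this read-out, even though the entering group has five heavy atoms and the leaving group one, and the entering group also adds a hydrogen-bond acceptor. No supporting measurement bears on this result, so it stands as a plain observation with no explanation attached.

On these data alone, whether a different kind of group on this aromatic carbon, such as an amine or a carboxylic acid, would shift the number beyond the scatter remains open. Among the compounds shown here, also open is whether this same exchange would read alike on another core, as only this one pair carries it.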